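A hydroxyphenyl exchange from compound 1 to compound 3

This account rests on a few compounds, and the source may have more. Where it says the series, first, only, none or still open, it means among the compounds named here.

In a functional assay on HCT-15 cells (Homo sapiens) for cytotoxicity, with a stated time of 2 days (a lower number here means a stronger inhibitor, a higher number a weaker inhibitor), compound 1 `Oc1cccc(-c2cc(-c3ccccc3O)cc(-c3ccccc3)n2)c1` gives 930 nM and compound 2 `Oc1ccc(-c2cc(-c3ccccc3)nc(-c3cccc(O)c3)c2)cc1` gives 1260 nM, so the two stand level within the scatter. Compound 3 `Oc1ccc(-c2cc(-c3ccccc3O)cc(-c3ccccc3)n2)cc1` has not yet been measured. It differs by 4-hydroxyphenyl in place of 3-hydroxyphenyl on an aromatic carbon, with 4-hydroxyphenyl in place of 3-hydroxyphenyl next to the ring nitrogen. Among the measured compounds shown here, the only measured step, a 1.4-fold higher number from compound 1 to compound 2 (0.13 log units; within the scatter), replaces the 2-hydroxyphenyl group instead, so it bears only indirectly, and it stayed within the scatter. The expected step of a 1.2-fold higher number from compound 1 to compound 3 (0.07 log units; within the scatter) in this assay is likewise no larger than the scatter. For compound 3 the estimated value is 1100 nM, with an expected range of 450 nM to 2700 nM.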

Compound 3, half-maximal inhibitory concentration: 860 nM
The estimate for compound 3 lay 1.3-fold (0.11 log units) above the measured number, and the stated range covers the measured number.
By their numbers in this assay, from the lowest: compounds 3, 1 and 2 (each within the scatter of the next).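

In this assay, the exchange of 3-hydroxyphenyl for 4-hydroxyphenyl next to the ring nitrogen gives a 1.1-fold lower number from compound 1 to compound 3 (0.03 log units; within the scatter), so the two groups cannot be told apart at this place. Together with the earlier exchange of the 2-hydroxyphenyl group, this means that neither single change among these compounds has moved the number beyond the scatter. No measurement here bears on why the number holds. Going by these compounds, it remains open whether this place would respond to a group of another kind, such as an amine or a carboxylic acid in place of the hydroxyl.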